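This account rests on a few compounds, and the source may have more. Where it says the series, first, only, none or still open, it means among the compounds named here.

In an ADME assay on Vero cells (Chlorocebus sabaeus) for cytotoxicity, read by resazurin assay, with a stated time of 72 h (a higher number here means a weaker inhibitor, a lower number a stronger inhibitor), compound 1 (`COc1ccc(C(=O)CCN2CCN(c3ccc([N+](=O)[O-])cc3)CC2)cc1`) gives 587000 nM and compound 2 (`O=C(CCN1CCN(c2ccc(F)cc2)CC1)c1ccc(F)c(Br)c1`) gives 352000 nM and the two values lie within the scatter of each other. Compound 3 (`O=C(CCN1CCN(c2ccc([N+](=O)[O-])cc2)CC1)c1ccc(F)c(Br)c1`) is not yet measured and differs from compound 2 by nitro in place of fluoro on an aromatic carbon in one place, nitro in place of fluoro on an aromatic carbon, para to a large group. The 4-nitrophenyl of compound 3 also stands in compound 1 at 587000 nM so no step beyond the scatter is expected in this assay in either direction. For compound 3 the estimated value is 420000 nM with an expected range from 180000 nM to 900000 nM for repeat measurements.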

Compound 3, half-maximal inhibitory concentration: 256000 nM
Compound 3: middle estimate off by 1.6-fold (0.22 log units), on the high side; low and high end bracket the measured number.
By their numbers in this assay, from the lowest: compounds 3, 2 and 1 (each within the scatter of the next, the first and the last beyond it).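

In this assay, within the data shown here, the change from 4-fluorophenyl to 4-nitrophenyl gives a 1.4-fold lower number from compound 2 to compound 3 (0.14 log units; within the scatter) and so leaves no step at this aromatic carbon that stands clear of the scatter. With the 4-nitrophenyl held fixed, 3-bromo-4-fluorophenyl in place of 4-methoxyphenyl on the carbonyl carbon gives a 2.3-fold lower number from compound 1 to compound 3 (0.36 log units; beyond the scatter) and this modest step is the only one beyond the scatter. No measured evidence explains either step.

Still open, from the compounds shown here alone, is whether an amine or a carboxylic acid on that aromatic carbon would also stay within the scatter. Also open, going by these compounds, is whether bromo or fluoro carries the step on the carbonyl side.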